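Carbamate series on leukaemia cells: compound 4 pending

A few compounds are considered here, and "the series" means these few. Any claim that something is new, unique, unknown or untested is made for them only; others in the source may bear on it.

Measured so far:
compound 1 `N#C[Se]c1ccc(NC(=O)Oc2ccc(F)cc2)cc1`: 71100 nM
compound 2 `CCOC(=O)Nc1ccc([Se]C#N)cc1`: 68800 nM
compound 3 `CC(C)COC(=O)Nc1ccc([Se]C#N)cc1`: 68700 nM

All three numbers come from a functional assay on CCRF-CEM cells (Homo sapiens) for cytotoxicity, read by MTT assay, with a stated time of 72 h; on this read-out higher numbers stand for lower toxicity in this test and lower numbers for higher toxicity in this test. Compound 1 holds the highest of the three numbers, yet its gaps to compound 2 and to compound 3 are within the scatter, so the three stand together.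

Compound 4 `Cc1ccc(OC(=O)Nc2ccc([Se]C#N)cc2)cc1` differs from compound 1 by methyl in place of fluoro on an aromatic carbon. Going by the values given here, the only measured step, a 1.0-fold lower number from compound 2 to compound 3 (0.00 log units; within the scatter), sits on the chain carbon bound to oxygen, not on the aromatic ring, and it was flat. Among the compounds with values here, no measured step touches the aromatic carbon, so the expectation rests on the flatness of the series as a whole: the step of a 1.0-fold lower number from compound 1 to compound 4 (0.01 log units; within the scatter) is expected to stay within the scatter. Compound 4 is estimated at 70000 nM, with a range from 35000 nM to 140000 nM.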

Compound 4, concentration lethal to 50% of the cells: 72000 nM
Estimate against measurement, compound 4: 1.0-fold (0.01 log units) below; measured number inside the range.
By their numbers in this assay, from the lowest: compounds 3, 2, 1 and 4 (each within the scatter of the next).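

Working notes: at the aromatic carbon para to a large group, this assay gives a 1.0-fold higher number from compound 1 to compound 4 (0.01 log units; within the scatter) for methyl in place of fluoro. Going by these compounds alone, this is the first step read on the aromatic ring, and like the chain step a 1.0-fold lower number from compound 2 to compound 3 (0.00 log units; within the scatter), it stays within the scatter, so exchanging these two groups leaves the read-out flat at this position. Nothing available accounts for this flatness.

Still open, from the compounds shown here alone, is whether an amine, a carboxylic acid or a longer chain at this ring position would stay within the scatter. The compounds shown include no step beyond it.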